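This account rests on a few compounds, and the source may have more. Where it says the series, first, only, none or still open, it means among the compounds named here.

Compound 1 `Oc1cccc(-c2cc(-c3ccccc3F)cc(-c3ccccc3O)n2)c1` carries a 2-fluorophenyl group; in a functional assay on HeLa cells (Homo sapiens) for inhibition (a lower number here means a stronger inhibitor, a higher number a weaker inhibitor), compound 1 gives 31100 nM. Compound 2 `Oc1cccc(-c2cc(-c3cccc(F)c3)cc(-c3ccccc3O)n2)c1` differs by 3-fluorophenyl in place of 2-fluorophenyl on an aromatic carbon. In this assay compound 2 gives > 50000 nM, a limit of the assay and not a number. The step is an at least 1.6-fold higher number from compound 1 to compound 2 (0.20 log units; that floor lies within the scatter); note that two of the three values sit at the limit of > 50000 nM in this assay, at which 2 of the 3 values shown sit. Compound 3 `Oc1ccc(-c2cc(-c3ccccc3F)cc(-c3ccc(O)cc3)n2)cc1` rests on another core; the difference between the two cores is not broken down here. In this assay compound 3 gives > 50000 nM, again a limit of the assay. Compound 4 `Oc1ccc(-c2cc(-c3cccc(F)c3)cc(-c3ccc(O)cc3)n2)cc1` is unmeasured and differs from compound 3 by 3-fluorophenyl in place of 2-fluorophenyl on an aromatic carbon, the same kind of change, here meta to two 4-hydroxyphenyl groups rather than meta to a 2-hydroxyphenyl group and meta to a 3-hydroxyphenyl group. For compound 4 the expected step in this assay is a step that the limit leaves unreadable from compound 3 to compound 4, resting on compound 3 already giving > 50000 nM and on the earlier step of an at least 1.6-fold higher number from compound 1 to compound 2 (0.20 log units; that floor lies within the scatter). Compound 4 is therefore expected to give 90000 nM in this assay, most likely again as a limit, with an estimated range from 35000 nM to 300000 nM.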

Compound 4, half-maximal inhibitory concentration: > 50000 nM
Compound 4: only a limit was reported; the forecaster's own chance of this, stated with the estimate: 85%; the middle value is on the limit's open side.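

In this assay compound 4 gives > 50000 nM, a limit and not a number. Going by these compounds alone, compound 3 also stands at a limit, so no step between compound 3 and compound 4 can be read. Whether 3-fluorophenyl in place of 2-fluorophenyl changes inhibition on this core stays open, as does most of the ranking within the series: the limit of > 50000 nM in this assay, at which 3 of the 4 values shown sit.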